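Trifluoromethyl for Methyl on an Aromatic Ring Oxygen

A few compounds are considered here, and "the series" means these few. Any claim that something is new, unique, unknown or untested is made for them only; others in the source may bear on it.

Two measured compounds share one core. Compound 1 `COc1ccc(/C=C2\CCC=CC2=O)cc1` gives 2570 nM in a functional assay on MCF7 cells (Homo sapiens) for antiproliferative activity, read by sulforhodamine B assay, with a stated time of 72 h (on this read-out higher numbers stand for weaker inhibition and lower numbers for stronger inhibition), and compound 2 `COc1cccc(/C=C2\CCC=CC2=O)c1` gives 2030 nM in this assay. Compound 1 holds the higher of the two numbers, yet its nearest neighbour, compound 2, lies within the usual scatter, so the two cannot be told apart on these data. Compound 3 `O=C1C=CCC/C1=C\c1ccc(OC(F)(F)F)cc1` is not yet measured. It differs from compound 1 in one place: trifluoromethyl in place of methyl on an oxygen on an aromatic ring. Among the measured compounds shown here, no measured pair shows this change, so nothing in the data tells its direction. For the measured compounds named here, with no reference step available, the estimate for compound 3 in this assay is 2500 nM, with an expected range from 900 nM to 7000 nM. The expected step of a 1.0-fold lower number from compound 1 to compound 3 (0.01 log units; within the scatter) is therefore one anticipated to stay within the scatter, in either direction.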

Compound 3, half-maximal inhibitory concentration: 1040 nM
For compound 3 the middle estimate is 2.4-fold (0.38 log units) above the measured one, within the range that was stated.
By their numbers in this assay, from the lowest: compounds 3, 2 and 1 (each within the scatter of the next, the first and the last beyond it).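

Trifluoromethyl in place of methyl on an oxygen on an aromatic ring gives the first step that can be read in this assay: a 2.5-fold lower number from compound 1 to compound 3 (0.39 log units; beyond the scatter), which is modest in size. The earlier compounds shown here both carried methoxy, so they could not show whether a change on this oxygen alters the read-out. This pair shows that it does, and that methoxy to trifluoromethoxy moves the number towards stronger inhibition. Nothing available offers an explanation for this step.

From the compounds shown here alone, whether the same change on the oxygen of compound 2 gives a step of similar size remains open. Also open, going by these compounds, is how this assay would respond to a hydroxyl, an ethoxy group or an amine on the aromatic ring.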